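The source may hold more compounds than are shown below. What is called first, only, known or untested is meant among the compounds shown, and "the series" means these compounds.

Compound 1 `O=S1(=O)c2ccccc2CN1c1cc(F)cc(OCc2ccccc2)c1` gives the lowest of the three numbers in a functional assay on Flp-In T-REx293 cells for antagonist activity at Free fatty acid receptor 1 (Homo sapiens), read by calcium flux (a lower number here means a smaller maximal response, a higher number a larger maximal response), namely 36%. Compound 2 `O=S(=O)(Nc1ccc(Oc2ccccc2)cc1)c1ccc(F)cc1` gives 95% and compound 3 `Cc1ccc(S(=O)(=O)Nc2ccc(Oc3ccccc3)cc2)cc1` gives 100%, so compound 1 sits far beneath both of them. Compound 4 `Cc1ccc(Oc2cc(F)cc(N3Cc4ccccc4S3(=O)=O)c2)cc1` differs from compound 1 in one place: 4-methylphenyl in place of benzyl on an oxygen on an aromatic ring. Going by the values given here, the only measured step, a number 5 percentage points higher from compound 2 to compound 3 (within the scatter), concerns a different change on a different scaffold, so no measured step bears directly on putting 4-methylphenyl in place of benzyl. With nothing pointing either way, compound 1 serves as the anchor, and no step beyond the scatter is expected, which the estimate expresses as a number 2 percentage points higher from compound 1 to compound 4 (within the scatter). Compound 4 is therefore expected to give 38%, with a range from 20% to 62%.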

Compound 4, largest response reached (reported as Imax), in percent of the reference or control that the assay uses: 52%
Estimate against measurement, compound 4: 14 percentage points below, and the stated range covers the measured number.
By their numbers in this assay, from the lowest: compound 1; then compound 4; then compounds 2 and 3 (each within the scatter of the next).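

Replacing benzyl with 4-methylphenyl on the oxygen gives a number 16 percentage points higher from compound 1 to compound 4 (beyond the scatter) in this assay, so this position responds to the change even though the two groups are made of the same atoms. The earlier step between compound 2 and compound 3 stayed within the scatter, and on a different scaffold, so this is the first change shown to move the response at this position. No measured evidence explains the shift.

As far as these compounds go, it remains open whether the methyl contributes to the step or the change from benzyl to an aryl group accounts for it alone. A plain phenyl on the oxygen would separate the two, and a carboxylic acid on that ring would test the position further.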